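Thiophene for Tolyl on a Weakly Cytotoxic Core

A few compounds are considered here, and "the series" means these few. Any claim that something is new, unique, unknown or untested is made for them only; others in the source may bear on it.

Compound 1 `Cc1ccc(-c2cn(/N=C/c3cc4ccccc4nc3Cl)c(N)n2)cc1`: > 50000 nM
Compound 2 `Cc1ccc(-c2cn(/N=C/c3cc4cc(C)ccc4nc3Cl)c(N)n2)cc1`: 18000 nM

In an ADME assay on HUVEC cells (Homo sapiens) for cytotoxicity, read by MTT assay, with a stated time of 48 h (a higher number here means a weaker inhibitor, a lower number a stronger inhibitor), compound 1 gives > 50000 nM, which is a limit of the assay and not a number. Compound 1 thus sits at the limit of > 50000 nM in this assay, at which 1 of the 2 values shown sits. Compound 2 in this assay gives 18000 nM. Among the compounds with values here, the one measured step, an at least 2.7-fold lower number from compound 1 to compound 2 (0.44 log units; beyond the scatter), concerns a methyl on the shared core and does not touch the aryl group changed here. Compound 3 `Nc1nc(-c2cccs2)cn1/N=C/c1cc2ccccc2nc1Cl` differs from compound 1 by thiophen-2-yl in place of 4-methylphenyl on an aromatic carbon. Within the data shown here, with no measured step covering this change, for compound 3 no move beyond the scatter is expected, a number no higher from compound 1 to compound 3 (the limit leaves the size open). Compound 3 is therefore estimated at 50000 nM, between 20000 nM and 120000 nM.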

Compound 3, half-maximal inhibitory concentration: 10200 nM
For compound 3 the middle estimate is 4.9-fold (0.69 log units) above the measured one, and the stated range ends above it.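

In this assay, within the data shown here, the earlier compounds showed a change only on the shared core, whereas this carbon of the five-membered aromatic ring also proves able to shift the number: thiophen-2-yl in place of 4-methylphenyl gives an at least 4.9-fold lower number from compound 1 to compound 3 (0.69 log units; beyond the scatter), a step beyond the scatter. From the compounds shown here alone, its full size stays open because compound 1 stands at a limit of the assay: the limit of > 50000 nM in this assay, at which 1 of the 3 values shown sits.

The compounds shown leave open whether a phenyl group carrying an amine or a carboxylic acid would shift the number at this carbon. They also leave open whether thiophen-2-yl acts alike on the methyl-bearing core of compound 2.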